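Series notes: amide tail variation on the spiro core

This account rests on a few compounds, and the source may have more. Where it says the series, first, only, none or still open, it means among the compounds named here.

Measured so far in an assay on HEK293 cells for displacement of a labelled ligand from NPC1-like intracellular cholesterol transporter 1 (Homo sapiens); on this read-out lower numbers stand for stronger inhibition and higher numbers for weaker inhibition:
compound 1 `CC(C)(C)c1ccc(C(=O)N2CCC3(CC2)C(=O)N(CC(=O)N2CCC(O)CC2)CN3c2ccccc2)cc1` gives 4700 nM
compound 2 `CCc1nn(CC)c(C2CCN(C(=O)CN3CN(c4ccccc4)C4(CCN(C(=O)c5ccc(C(C)(C)C)cc5)CC4)C3=O)CC2)c1CC` gives 4600 nM
compound 3 `CCc1nn(CC)c(C2CCN(C(=O)CN3CN(c4ccccc4)C4(CCN(C(=O)c5ccc(C(C)(C)C)cc5)CC4)C3=O)CC2)c1C` gives 2500 nM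

Compound 1 has the highest number of the three, yet all three lie within the scatter of one another: a 1.0-fold lower number from compound 1 to compound 2 (0.01 log units; within the scatter) and a 1.9-fold lower number from compound 1 to compound 3 (0.27 log units; within the scatter) are both inside it, as is a 1.8-fold lower number from compound 2 to compound 3 (0.26 log units; within the scatter). Nothing here separates the three compounds.

The next compound, compound 4 `CC(C)(C)c1ccc(C(=O)N2CCC3(CC2)C(=O)N(CC(=O)NCCCCN)CN3c2ccccc2)cc1`, keeps the shared core of compound 1 and alters the tail on the carbonyl carbon:

(4-aminobutyl)amino in place of 4-hydroxypiperidin-1-yl on a carbonyl carbon

Among the compounds with values here, no measured step covers this exchange. The two steps that start from compound 1 change the same region of the molecule, replacing the hydroxy on the saturated ring carbon with a pyrazolyl group, and both stay within the scatter. Within the data shown here, that the tail tolerates a large group change without a shift in this assay is the only guide; an open chain with a second hydrogen-bond donor in place of the ring is a different kind of change, and the steps from compound 1 say nothing direct about it.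

Compound 4 is therefore expected to stay near compound 1, with a step of a 1.0-fold lower number from compound 1 to compound 4 (0.02 log units; within the scatter) at most within the scatter. The estimate for compound 4 in this assay is 4500 nM, expected to fall between 1500 nM and 14000 nM.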

Compound 4, half-maximal inhibitory concentration: 14500 nM
Compound 4: middle estimate off by 3.2-fold (0.51 log units), on the low side; measured number above the stated range.
By their numbers in this assay, from the lowest: compounds 3, 2 and 1 (each within the scatter of the next); then compound 4.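

In this assay, within the data shown here, the step of a 3.1-fold higher number from compound 1 to compound 4 (0.49 log units; beyond the scatter) is the first to lie beyond the scatter, so the group on the carbonyl carbon is not free to vary without limit, as the steps among compound 1, compound 2 and compound 3 alone might have implied. The change from 4-hydroxypiperidin-1-yl to (4-aminobutyl)amino gives a modest loss of inhibition, and it removes a six-membered non-aromatic ring while bringing in an open chain with more hydrogen-bond donors, so this single step cannot tell these two differences apart. Nothing available bears on the reason for the shift.

Still open, as far as these compounds go, is whether the loss goes with the open chain or with the amine, which a (4-hydroxybutyl)amino group or a piperidin-1-yl ring carrying an amine in place of the hydroxy would help to separate. Also open, from the compounds shown here alone, is whether a longer chain, or a carboxylic acid in place of the amine, would move the number further or bring it back towards that of compound 1.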